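Alkyne-linked uracil series: double-bond geometry step

The compounds below may be only part of what the source reports. "The series", "measured", "known", "first", "only" and "open" are said of these compounds alone.

Measured so far in a functional assay on MOLT-4 cells (Homo sapiens) for antiproliferative activity, read by MTT assay, with a stated time of 3 days; on this read-out higher numbers stand for weaker inhibition and lower numbers for stronger inhibition:
compound 1 `O=C1c2ccccc2C(=O)N1C/C=C\Cn1cc(C#Cc2ccc(Br)cc2)c(=O)[nH]c1=O` gives 89000 nM
compound 2 `CCCCCc1ccc(C#Cc2cn(C/C=C\CN3C(=O)c4ccccc4C3=O)c(=O)[nH]c2=O)cc1` gives 30000 nM
compound 3 `CCCCc1ccc(C#Cc2cn(C/C=C/CN3C(=O)c4ccccc4C3=O)c(=O)[nH]c2=O)cc1` gives 29000 nM

Compound 3 has the lowest number of the three in this assay, but its value and that of compound 2 lie within the scatter of each other, so no order between the two can be read. Among the compounds with values here, compound 1 sits clearly higher; the one step measured so far, a 3.0-fold lower number from compound 1 to compound 2 (0.47 log units; beyond the scatter), concerns the replacement on the aromatic ring and not the linker.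

Compound 4 `CCCCc1ccc(C#Cc2cn(C/C=C\CN3C(=O)c4ccccc4C3=O)c(=O)[nH]c2=O)cc1` is the next candidate. The change from compound 3 is the two compounds have the same atoms and bonds and differ only in configuration as drawn: 1 of 1 stereo elements differ; a double bond is drawn E in compound 3 and Z in compound 4. Within the data shown here, no measured pair in the set isolates this change: compound 2 and compound 3 differ both in the double-bond geometry and in the chain on the aromatic ring, and their values are indistinguishable within the scatter. The pentyl-for-bromo step therefore bears only indirectly, by showing that the remaining part of the molecule is tolerant of the two geometries appearing in compound 2 and compound 3. With that, the expected step of a 1.0-fold higher number from compound 3 to compound 4 (0.01 log units; within the scatter) is none beyond the scatter. Compound 4 is accordingly estimated at 30000 nM in this assay, with a range from 12000 nM to 75000 nM.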

Compound 4, half-maximal inhibitory concentration: 31000 nM
Estimate against measurement, compound 4: 1.0-fold (0.01 log units) below; the measured number falls inside the stated range.
By their numbers in this assay, from the lowest: compounds 3, 2 and 4 (each within the scatter of the next); then compound 1.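

The pair of compound 3 and compound 4 is the first in the set to isolate the double-bond geometry, and in this assay the step from E to Z is a 1.1-fold higher number from compound 3 to compound 4 (0.03 log units; within the scatter), so no effect of geometry can be read with butyl on the aromatic ring, and the comparison carries no second change: the fact that compounds 3 and 4 differ only in the configuration as drawn

The chain length also gets its first isolated step with the Z linker held, a 1.0-fold higher number from compound 2 to compound 4 (0.01 log units; within the scatter), so butyl and pentyl cannot be told apart in this series. The step from bromo to butyl, a 2.9-fold lower number from compound 1 to compound 4 (0.46 log units; beyond the scatter), shows that compound 4, like compound 2, stands apart from the bromo compound, so the gap from compound 1 does not depend on the pentyl chain alone.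

Still open, going by these compounds, is whether the double-bond geometry stays as silent with bromo on the aromatic ring as it does with butyl. Also open, on these data alone, is whether a much longer chain, an amine or a carboxylic acid at the same place on the aromatic ring would move the number beyond the scatter of the butyl and pentyl compounds.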